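The source may report more compounds than this note shows. Statements on the series, on what has been measured and on what is new or still open speak of the compounds shown alone.

Measured compounds:
compound 1 `CC(=O)Nc1ccc(S(=O)(=O)Oc2ccccc2I)cc1` — 23000 nM
compound 2 `CC(C)C(=O)Nc1ccc(S(=O)(=O)Oc2ccccc2C(C)C)cc1` — 14000 nM
compound 3 `CC(C)C(=O)Nc1ccc(S(=O)(=O)Oc2ccccc2I)cc1` — 13000 nM

In a functional assay on HT-29 cells (Homo sapiens) for antiproliferative activity, read by sulforhodamine B assay, with a stated time of 48 h (on this read-out lower numbers stand for stronger inhibition and higher numbers for weaker inhibition), compound 3 gives the lowest number of the three, yet its neighbours sit close: the step from compound 2 a 1.1-fold lower number from compound 2 to compound 3 (0.03 log units; within the scatter) and the step from compound 1 a 1.8-fold lower number from compound 1 to compound 3 (0.25 log units; within the scatter) both lie within the scatter, so no ordering among the three can be claimed. Compound 4 `O=C(CCl)Nc1ccc(S(=O)(=O)Oc2ccccc2I)cc1` has not been measured. It differs from compound 3 in one place: chloromethyl in place of isopropyl on a carbonyl carbon. The measured step that bears most directly on this position is the one at the carbonyl carbon, from compound 1 to compound 3, where a 1.8-fold lower number from compound 1 to compound 3 (0.25 log units; within the scatter) was seen; exchanging one alkyl group for another at that place changed little. The exchange of iodo for isopropyl on the aromatic carbon, a 1.1-fold lower number from compound 2 to compound 3 (0.03 log units; within the scatter), was likewise flat. On this basis compound 4 is expected to stay near compound 3, with a step of a 1.1-fold lower number from compound 3 to compound 4 (0.03 log units; within the scatter) in this assay, no larger than the scatter. Compound 4 is therefore estimated at 12000 nM, with a range from 4000 nM to 36000 nM.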

Compound 4, half-maximal inhibitory concentration: 4100 nM
For compound 4 the middle estimate is 2.9-fold (0.47 log units) above the measured one; low and high end bracket the measured number.
By their numbers in this assay, from the lowest: compound 4; then compounds 3, 2 and 1 (each within the scatter of the next).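

In this assay, the carbonyl carbon proves not to be a flat position: chloromethyl in place of isopropyl gives a 3.2-fold lower number from compound 3 to compound 4 (0.50 log units; beyond the scatter), and chloro in place of hydrogen on the saturated chain carbon bound to that carbonyl carbon gives a 5.6-fold lower number from compound 1 to compound 4 (0.75 log units; beyond the scatter), whereas the exchange of one alkyl group for another had stayed within the scatter. Among the compounds shown, steps beyond the scatter at this place appear only with chloromethyl, and compound 4 is the sole compound that carries it. Nothing available explains this difference.

The compounds shown leave open whether another group on this chain carbon, such as bromo, a hydroxyl or an amine, or a longer chain ending in chloro, would give a similar step. From the compounds shown here alone, it also remains open whether the step would persist with isopropyl in place of iodo on the aromatic carbon.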